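The source may report more compounds than this note shows. Statements on the series, on what has been measured and on what is new or still open speak of the compounds shown alone.

In an assay for inhibition of 6-phosphofructo-2-kinase/fructose-2,6-bisphosphatase 3 (Homo sapiens), read by ADP-Glo, with a stated time of 2 h (on this read-out lower numbers stand for stronger inhibition and higher numbers for weaker inhibition), compound 1 `CNC(=O)c1ccncc1Nc1cc(-c2ccc3ccn(C)c3c2)c2nccnc2c1` gives 83 nM. Compound 2 `CC(=O)N1CCC(NC(=O)c2ccncc2Nc2cc(-c3ccc4ccn(C)c4c3)c3nccnc3c2)CC1` gives 18 nM, and compound 3 `CC(=O)N1CCCC(NC(=O)c2ccncc2Nc2cc(-c3ccc4ccn(C)c4c3)c3nccnc3c2)C1` gives 11 nM. Of these three numbers, that of compound 3 is the lowest: a 7.5-fold lower number from compound 1 to compound 3 (0.88 log units; beyond the scatter), yet a 1.6-fold lower number from compound 2 to compound 3 (0.21 log units; within the scatter), so compound 2 and compound 3 cannot be set apart from each other. Compound 4 `CC(=O)N1CCOC(CNC(=O)c2ccncc2Nc2cc(-c3ccc4ccn(C)c4c3)c3nccnc3c2)C1` is a close relative of compound 3; the difference is (4-acetylmorpholin-2-yl)methyl in place of 1-acetylpiperidin-3-yl on an amide-type nitrogen. The measured steps that bear on this are a 4.6-fold lower number from compound 1 to compound 2 (0.66 log units; beyond the scatter) and a 7.5-fold lower number from compound 1 to compound 3 (0.88 log units; beyond the scatter), which show that replacing the small methyl by an acetylated six-membered ring at this amide-type nitrogen lowered the number clearly, and a 1.6-fold lower number from compound 2 to compound 3 (0.21 log units; within the scatter), which shows that shifting the point of attachment within such a ring changed nothing beyond the scatter. Compound 4 keeps an acetylated six-membered ring on the same amide-type nitrogen. The expected step from compound 3 to compound 4 is therefore a 1.4-fold higher number from compound 3 to compound 4 (0.13 log units; within the scatter), not beyond the scatter. In this assay compound 4 is expected to give 15 nM, with a range from 6 nM to 40 nM.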

Compound 4, half-maximal inhibitory concentration: 93 nM
For compound 4 the middle estimate is 6.2-fold (0.79 log units) below the measured one; the whole stated range lies below it.
By their numbers in this assay, from the lowest: compounds 3 and 2 (each within the scatter of the next); then compounds 1 and 4 (each within the scatter of the next).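

In this assay, an acetylated six-membered ring on this amide-type nitrogen does not guarantee a low number: (4-acetylmorpholin-2-yl)methyl gives an 8.5-fold higher number from compound 3 to compound 4 (0.93 log units; beyond the scatter) and a 5.2-fold higher number from compound 2 to compound 4 (0.71 log units; beyond the scatter), while a 1.1-fold higher number from compound 1 to compound 4 (0.05 log units; within the scatter) leaves compound 4 impossible to set apart from the small methyl amide. So this position, which showed no change beyond the scatter when the point of attachment moved within the piperidine ring, does respond to this replacement, in which the ring gains a hetero atom and is also held through an added methyl link. Nothing available explains this rise in the number.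

The two parts of the change remain unseparated in the compounds shown. A (1-acetylpiperidin-3-yl)methyl group on the same nitrogen would test the added link alone, with the ring oxygen absent.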